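The source may hold more compounds than are shown below. What is called first, only, known or untested is meant among the compounds shown, and "the series" means these compounds.

The measured compounds and their values in a functional assay on HEp-2 cells (Homo sapiens) for antiproliferative activity, read by MTT assay, with a stated time of 72 h; on this read-out higher numbers stand for weaker inhibition and lower numbers for stronger inhibition:

Compound 1, `COc1ccc2occ(CSC(=S)N3CCCCC3)c(=O)c2c1`, gives 4300 nM.
Compound 2, `O=c1c(CSC(=S)N2CCCCC2)coc2cc(Cl)ccc12`, gives 280 nM.

Of the two numbers, compound 1 stands at the higher one, and the lower number of compound 2 lies beyond the usual scatter of repeated measurements, so on this read-out compound 2 is the stronger inhibitor of the pair. Going by the values given here, no single-change step between measured compounds is available, so nothing here shows how a change at the thiocarbonyl carbon moves the read-out.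

Compound 3, `COc1ccc2occ(CSC(=S)N3CCCC3)c(=O)c2c1`, is the unmeasured partner of compound 1. It differs from compound 1 in one place: pyrrolidin-1-yl in place of piperidin-1-yl on a thiocarbonyl carbon. As this change has no measured counterpart among the compounds shown, the expectation rests on the value of compound 1 alone. The step of a 1.1-fold lower number from compound 1 to compound 3 (0.03 log units; within the scatter) is expected to be small, in no particular direction, and most likely within the scatter of this assay. Compound 3 is therefore estimated to give about 4000 nM in this assay, with a range of 1500 nM to 12000 nM.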

Compound 3, half-maximal inhibitory concentration: 3100 nM
The estimate for compound 3 lay 1.3-fold (0.11 log units) above the measured number; low and high end bracket the measured number.
By their numbers in this assay, from the lowest: compound 2; then compounds 3 and 1 (each within the scatter of the next).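

In this assay, the step now available is a 1.4-fold lower number from compound 1 to compound 3 (0.14 log units; within the scatter), the first single change among these compounds and so the first direct reading at this position. Pyrrolidin-1-yl in place of piperidin-1-yl on a thiocarbonyl carbon therefore shifts the read-out by no more than repeated measurements would, at least on the core of compound 1. For this pair, the five-membered and six-membered rings cannot be told apart by this read-out, and no information on the reason for this result is available.

The compounds shown leave open whether a ring with a further hetero atom, such as morpholin-4-yl or piperazin-1-yl, or an open-chain group such as diethylamino, would also stay within the scatter of compound 1 at this position. They also leave open whether the same exchange of rings would stay as small on the core of compound 2, which gives 280 nM.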